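The source may hold more compounds than are shown below. What is called first, only, known or untested is meant among the compounds shown, and "the series" means these compounds.

Measured in a functional assay on A549 cells (Homo sapiens) for antiproliferative activity, read by sulforhodamine B assay, with a stated time of 3 days; a lower number here means a stronger inhibitor of growth, a higher number a weaker inhibitor of growth:
- compound 1 `O=C(Nc1nccs1)c1cccc(Nc2ncc(F)c(Nc3ccc(F)cc3)n2)c1`: > 10000 nM
- compound 2 `O=C(Nc1cccc(Nc2ncc(F)c(Nc3ccc(F)cc3)n2)c1)c1ccncc1`: 1650 nM

Compound 1 stands at a limit and not at a number: the limit of > 10000 nM in this assay, at which 1 of the 2 values shown sits.

The next compound to be read is compound 3 `COc1cc(NC(=O)c2cccc(Nc3ncc(F)c(Nc4ccc(F)cc4)n3)c2)cc(OC)c1`. It has 3,5-dimethoxyphenyl in place of 1,3-thiazol-2-yl on an amide-type nitrogen, and its core is otherwise that of compound 1: 3,5-dimethoxyphenyl in place of 1,3-thiazol-2-yl on an amide-type nitrogen.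

For the measured compounds named here, only one measured step bears on this, and only loosely. That step is an at least 6.0-fold lower number from compound 1 to compound 2 (0.78 log units; beyond the scatter), and it exchanges the whole (1,3-thiazol-2-yl)carbamoyl for ((pyridin-4-yl)carbonyl)amino on an aromatic carbon, rather than only the group on the amide-type nitrogen. Going by the values given here, with compound 2 at 1650 nM as the sole numerical guide, a modest move to a lower number in this assay is expected, of about the size of that step. A result for compound 3 at the same limit as compound 1 remains quite possible.

The estimated step is an at least 2.8-fold lower number from compound 1 to compound 3 (0.45 log units; beyond the scatter).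

For compound 3 the expected value is 3500 nM, with an estimated range of 900 nM to 10000 nM.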

Compound 3, concentration for 50% growth inhibition: 13900 nM
Compound 3: middle estimate off by 4.0-fold (0.60 log units), on the low side; measured number outside the range, above it.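

For the compounds shown here, no step from compound 1 to compound 3 can be read in this assay, because compound 1 stands at a limit and not at a number: the limit of > 10000 nM in this assay, at which 1 of the 3 values shown sits.

The compounds shown leave open how the 3,5-dimethoxyphenyl and 1,3-thiazol-2-yl groups on the amide-type nitrogen compare, including which of compound 1 and compound 3 has the lower number.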